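The source may hold more compounds than are shown below. What is called first, only, known or untested is meant among the compounds shown, and "the series" means these compounds.

Measured so far in a functional assay on the whole organism for inhibition, with Rattus norvegicus as the target; a lower number here means that less compound is needed, a higher number that more compound is needed for the effect:
- Compound 1, `CCOC(=O)c1cnc2n(c1=O)C(C)CC/C2=N\Nc1ccccc1`: compound 1 gives > 1000 umol/kg, a limit of the assay rather than a number.
- Compound 2, `CC1CCn2c(ncc(C(=O)O)c2=O)/C1=N/Nc1ccccc1`: compound 2 gives > 320 umol/kg, likewise a limit.
- Compound 3, `CC1CC/C(=N\Nc2ccc(F)cc2)c2ncc(C(=O)O)c(=O)n21`: compound 3 gives > 1000 umol/kg, also a limit.

Compound 3 thus stands at the limit of > 1000 umol/kg in this assay, at which 2 of the 3 values shown sit. Compound 2 sits at the limit of > 320 umol/kg in this assay, at which 1 of the 3 values shown sits. Going by the values given here, no compound in this assay has yet returned a number, so no step between measured compounds can be drawn; the values of compounds 1 and 2 show only that neither reaches half inhibition within the tested dose range.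

Compound 4, `Cc1ccc(N/N=C2\CCC(C)n3c2ncc(C(=O)O)c3=O)cc1`, differs from compound 3 by methyl in place of fluoro on an aromatic carbon. Among the compounds with values here, every value so far is a limit. Within the data shown here, the data hold no measured step that shows how this kind of change moves the dose, and nothing supports a shift in either direction. The step from compound 3 to compound 4 in this assay is expected to be a step that the limit leaves unreadable from compound 3 to compound 4, none beyond the scatter. For compound 4 the estimate in this assay is 1500 umol/kg, with a range from 500 umol/kg to 5000 umol/kg, and most probably the result is again reported only as a limit.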

Compound 4, dose for 50% inhibition: > 1000 umol/kg
Compound 4 was reported as a limit; the forecaster's own chance of this, stated with the estimate: 80%; the middle value is on the limit's open side.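

Going by these compounds alone, compound 3 and compound 4 both return limits rather than numbers in this assay, and no step between them can be read. The compounds shown leave open what dose gives half inhibition for any of them, and whether methyl in place of fluoro on an aromatic carbon moves that dose.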